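The source may report more compounds than this note shows. Statements on the series, on what has been measured and on what is new or still open speak of the compounds shown alone.

Compounds measured so far:
Compound 1 `N#CC1=C(N)N(c2ccc(S(N)(=O)=O)cc2)C2=C(C(=O)CCC2)C1/C=C/c1ccccc1` gives 45% in a functional assay on Ehrlich cells (Mus musculus) for antiproliferative activity, read by trypan blue exclusion, with a stated time of 2 h, tested at 100 ug/mL; on this read-out higher numbers stand for a stronger effect at the one concentration tested and lower numbers for a weaker effect.
Compound 2 `N#CC1=C(N)N(c2ccc(S(N)(=O)=O)cc2)C2=C(C(=O)CCC2)C1c1c(O)ccc2ccccc12` gives 15% in this assay.

Compound 1 has the higher of the two numbers. Going by the values given here, its nearest neighbour is compound 2, and the only step between them, a number 30 percentage points lower from compound 1 to compound 2 (beyond the scatter), is beyond the scatter; it goes with the exchange of the 2-phenylethenyl group for 2-hydroxynaphthalen-1-yl on a saturated ring carbon of the shared core.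

Compound 3 `N#CC1=C(N)N(c2ccc(S(N)(=O)=O)cc2)C2=C(C(=O)CCC2)C1c1ccco1` is not yet measured. It differs from compound 1 in one place: furan-2-yl in place of 2-phenylethenyl on a saturated ring carbon.

Among the compounds with values here, only one measured step bears on this change, since the group that leaves is the same one that left in going from compound 1 to compound 2, and that step, a number 30 percentage points lower from compound 1 to compound 2 (beyond the scatter), lowered the read-out. Within the data shown here, the group that enters in compound 3 differs from the one that entered in compound 2, so the step cannot be carried over directly; it only shows that a change at this position can lower the number well beyond the scatter.

Compound 3 is therefore expected to show a modest decrease, a number 15 percentage points lower from compound 1 to compound 3 (beyond the scatter), in this assay. The estimate for compound 3 is 30%, with a range from 10% to 55%.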

Compound 3, a percentage reported as activity, at one concentration (the size of the read-out at that concentration, not a potency): 10%
For compound 3 the middle estimate is 20 percentage points above the measured one; the range from low to high includes it.
By their numbers in this assay, from the lowest: compounds 3 and 2 (each within the scatter of the next); then compound 1.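

The second replacement of 2-phenylethenyl on this saturated ring carbon gives the same direction of change in this assay, with furan-2-yl producing a number 35 percentage points lower from compound 1 to compound 3 (beyond the scatter), so the lower number no longer rests on 2-hydroxynaphthalen-1-yl alone. The two entering groups differ in their rings, yet they cannot be told apart on this read-out, as the comparison gives a number 5 percentage points lower from compound 2 to compound 3 (within the scatter), and among these three compounds only 2-phenylethenyl stands apart from the others. Nothing available explains why the exchange of this group goes with the lower number.

The compounds shown leave open whether the higher number of compound 1 belongs to the 2-phenylethenyl group as a whole, to its double bond outside aromatic rings, or to its six-membered aromatic ring, a question on which a plain phenyl or a saturated 2-phenylethyl chain at this ring carbon would bear. They also leave open whether any other group at this position, such as a longer alkyl chain or one ending in an amine or a carboxylic acid, would match or exceed the read-out of compound 1, and how any of these results would look at other concentrations.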